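Moving a methylpyridinyl sulfonyl group's point of attachment

This account rests on a few compounds, and the source may have more. Where it says the series, first, only, none or still open, it means among the compounds named here.

Measured compounds:
compound 1 `CNCc1cc(-c2cccnc2F)n(S(=O)(=O)c2ccsc2)c1`: -0.83
compound 2 `CNCc1cn(S(=O)(=O)c2ncccc2C)c(-c2cccnc2F)c1F`: 0.32

Of the compounds shown here, two have been measured in a physicochemical assay for lipophilicity, read by HPLC, at pH 7.4; a higher number here means a more lipophilic compound, a lower number a more polar compound. Compound 1 gives -0.83, and compound 2 gives 0.32. For the measured compounds named here, of the two, compound 2 stands highest, with compound 1 lower by a gap that lies beyond the scatter; no single-point step links these two, so only their values can be compared.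

Compound 3 `CNCc1cn(S(=O)(=O)c2cncc(C)c2)c(-c2cccnc2F)c1F` has not yet been measured in this assay. It differs from compound 2 in one place: 5-methylpyridin-3-yl in place of 3-methylpyridin-2-yl on a sulfonyl sulfur. Going by the values given here, the two have the same atoms, joined differently, and nothing measured so far speaks to such a rearrangement. A step of a number 0.12 log units lower from compound 2 to compound 3 (within the scatter) is expected, which means no change beyond the scatter. Compound 3 is therefore estimated to give 0.2, within a range from -0.3 to 0.7.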

Compound 3, distribution coefficient: 0.61
The estimate for compound 3 lay 0.41 log units below the measured number; measured number inside the range.
By their numbers in this assay, from the lowest: compound 1; then compounds 2 and 3 (each within the scatter of the next).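

The first step read at this position is the one on the sulfonyl sulfur, whose other neighbours are aromatic nitrogen: in this assay, 5-methylpyridin-3-yl in place of 3-methylpyridin-2-yl gives a number 0.29 log units higher from compound 2 to compound 3 (within the scatter). Compound 2 and compound 3 therefore cannot be told apart in this read-out, so for this one pair, moving the point of attachment of a methylpyridinyl group on the sulfonyl sulfur leaves no change beyond the scatter. Nothing available bears on why the two compounds read alike.

This single pair cannot show whether the same holds for other rearrangements of the methylpyridinyl group. It also leaves open how this assay would respond if a different group stood on the sulfonyl sulfur, such as a pyridine carrying an amine or a carboxylic acid.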